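The source may report more compounds than this note shows. Statements on the series, on what has been measured and on what is new or still open speak of the compounds shown alone.

Measured so far:
compound 1 `Cc1cc(C(=O)O)ccc1OCCCCOc1ccc(C(=O)CC(C)C)c(O)c1C` — 192 nM
compound 2 `COc1cc(C(=O)O)ccc1OCCCCOc1ccc(C(=O)CC(C)C)c(O)c1C` — 40 nM

In an assay on HEK293 cells for positive allosteric modulation of metabotropic glutamate receptor 2 (Rattus norvegicus), read by thallium flux, with a stated time of 2.5 min (on this read-out lower numbers stand for an effect already at smaller amounts and higher numbers for an effect only at larger amounts of compound), compound 1 gives 192 nM and compound 2 gives 40 nM. Among the compounds with values here, compound 2 thus stands at the lower of the two numbers, and the step of a 4.8-fold lower number from compound 1 to compound 2 (0.68 log units; beyond the scatter) separates it from compound 1, which is the only other measured compound.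

Compound 3 `COc1cc(C(=O)O)ccc1OCCCCOc1ccc(C(C)=O)c(O)c1C` is not yet measured. It differs from compound 2 in one place: hydrogen in place of isopropyl on a saturated chain carbon bound to a carbonyl carbon, the same difference read one bond further out as isobutylcarbonyl to acetyl. Within the data shown here, no measured step bears on this change: the single step so far, from compound 1 to compound 2, alters a substituent on an aromatic carbon and leaves the ketone chain untouched, so nothing shows how shortening that chain acts on the number.

For compound 3 the number in this assay is therefore estimated, with little support, at 200 nM, within 40 nM to 1200 nM. That estimate for compound 3 amounts to an expected step of a 5.0-fold higher number from compound 2 to compound 3 (0.70 log units; beyond the scatter), a weakening that may exceed the scatter, with the range kept wide to allow for either direction.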

Compound 3, half-maximal effective concentration: 161 nM
For compound 3 the middle estimate is 1.2-fold (0.09 log units) above the measured one; the range from low to high includes it.
By their numbers in this assay, from the lowest: compound 2; then compounds 3 and 1 (each within the scatter of the next).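

Within the data shown here, replacing isopropyl with hydrogen on the saturated chain carbon bound to the carbonyl carbon, read one bond further out as isobutylcarbonyl to acetyl, gives in this assay a 4.0-fold higher number from compound 2 to compound 3 (0.60 log units; beyond the scatter) and so provides the first reading for this part of the molecule. The number at this position is therefore sensitive to the group carried there, whereas the earlier pair, which differed only by methoxy in place of methyl on an aromatic carbon, held the isobutylcarbonyl group constant and could not show this. No measurement available here explains the change, and the step records only its size and direction in this single matched pair.

The compounds shown give only the two end points, isopropyl and hydrogen, so it remains open whether a single methyl, an ethyl, a longer chain, a cyclopropyl ring or an amine at this carbon would give a number nearer that of compound 2 or compound 3. It is also open whether the step from methyl to methoxy on the aromatic carbon would keep its size with acetyl, since the compounds shown contain that change only with isobutylcarbonyl.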